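Pyrazole carboxylic acids: aryl swap from compound 3 to 4

A few compounds are considered here, and "the series" means these few. Any claim that something is new, unique, unknown or untested is made for them only; others in the source may bear on it.

Measured so far in a functional assay on BJAB cells (Homo sapiens) for antiproliferative activity, with a stated time of 4 days; a higher number here means that more compound is needed for the effect, a lower number that less compound is needed:
- compound 1 `COc1cc(-c2c(C)nn(-c3nc(-c4ccc(Cl)c(Cl)c4)c(SC(C)C)s3)c2C(=O)O)cc(C(F)(F)F)c1`: 1380 nM
- compound 2 `COc1ccc(-c2c(C)nn(-c3nc(-c4ccc(Cl)c(Cl)c4)c(SC(C)C)s3)c2C(=O)O)cc1`: 2100 nM
- compound 3 `Cc1nn(-c2nc(-c3ccc(Cl)c(Cl)c3)c(SC(C)C)s2)c(C(=O)O)c1-c1cncc(C#N)c1`: 20000 nM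

Compound 3 carries the highest number of the three in this assay; its nearest neighbour is compound 2, and the gap to compound 1 is wider still, both beyond the scatter. Compound 4 `Cc1nn(-c2nc(-c3ccc(Cl)c(Cl)c3)c(SC(C)C)s2)c(C(=O)O)c1-c1ccc(Cl)cc1` is unmeasured and differs from compound 3 in one place: 4-chlorophenyl in place of 5-cyanopyridin-3-yl on an aromatic carbon.

The two steps that bear on this change both run into compound 3 with the 5-cyanopyridin-3-yl group entering: a 14-fold higher number from compound 1 to compound 3 (1.16 log units; beyond the scatter) and a 9.5-fold higher number from compound 2 to compound 3 (0.98 log units; beyond the scatter). Compound 4 reverses that direction, putting a carbon-only six-membered aromatic ring back on the core. Among the phenyl-bearing compounds, a 1.5-fold higher number from compound 1 to compound 2 (0.18 log units; within the scatter) shows that changing the substituents on that ring did little. A step downward in this assay of roughly the size seen in the pyridyl steps is therefore expected, with the number of compound 4 landing close to compound 2 and compound 1. The expected step is a 10-fold lower number from compound 3 to compound 4 (1.00 log units; beyond the scatter). For compound 4 the estimate in this assay is 2000 nM, expected range 800 nM to 5000 nM.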

Compound 4, half-maximal effective concentration: 2500 nM
Beside the measured number, compound 4's estimate is 1.3-fold (0.10 log units) below it; low and high end bracket the measured number.
By their numbers in this assay, from the lowest: compounds 1, 2 and 4 (each within the scatter of the next); then compound 3.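

The earlier steps shown here in this assay only showed the 5-cyanopyridin-3-yl group entering; now an 8.0-fold lower number from compound 3 to compound 4 (0.90 log units; beyond the scatter) reads the change in the opposite direction, with a chlorine-bearing ring of carbon only on the aromatic carbon of the five-membered aromatic ring. With a 1.2-fold higher number from compound 2 to compound 4 (0.08 log units; within the scatter) and a 1.8-fold higher number from compound 1 to compound 4 (0.26 log units; within the scatter) both within the scatter, 4-chlorophenyl, 4-methoxyphenyl and 3-methoxy-5-(trifluoromethyl)phenyl cannot be told apart at this position, so the phenyl groups of compound 1, compound 2 and compound 4 form one level. Compound 3 alone stands apart from that level, which shows that the gap does not depend on methoxy or trifluoromethyl being present on the phenyl ring, although this pattern rests on these four compounds only.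

Nothing available explains why the 5-cyanopyridin-3-yl group separates from the phenyl groups. As far as these compounds go, whether the ring nitrogen or the nitrile sets compound 3 apart remains open, as does whether a pyridin-3-yl without the nitrile, a 3-cyanophenyl, or a phenyl ring carrying an amine or a carboxylic acid would fall with compound 3 or with compound 4.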